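The source may report more compounds than this note shows. Statements on the series, on what has been measured and on what is new or still open speak of the compounds shown alone.

Going by the values given here, compound 2 `C[C@@H](Cn1ccc(-c2ccc(C#N)c(Cl)c2)n1)NC(=O)C1CC(=O)C1` gives 22500 nM in a functional assay on VCaP cells (Homo sapiens) for antiproliferative activity, read by CCK-8 assay, with a stated time of 6 days (a higher number here means a weaker inhibitor, a lower number a stronger inhibitor), the highest of the two numbers measured so far, while compound 1 `CC(=O)c1ccc(C(=O)N[C@@H](C)Cn2ccc(-c3ccc(C#N)c(Cl)c3)n2)cc1` gives 1400 nM. Among the compounds with values here, the only measured step, a 16-fold higher number from compound 1 to compound 2 (1.21 log units; beyond the scatter), shows that what sits on the carbonyl carbon changes the result strongly. Compound 3 `C[C@@H](Cn1ccc(-c2ccc(C#N)c(Cl)c2)n1)Nc1ncnc2nc[nH]c12` differs from compound 2 in one place: a group of 9 heavy atoms (5 carbon, 4 nitrogen; one five-membered aromatic ring with 2 hetero atoms, one six-membered aromatic ring with 2 hetero atoms) in place of a group of 7 heavy atoms (5 carbon, 2 oxygen; one four-membered non-aromatic ring of carbon only), on an amine nitrogen. Within the data shown here, no measured step covers a change of this kind, but since compound 1, whose carbonyl carbon bears 4-acetylphenyl, gives 1400 nM, a large drop is expected for compound 3, namely a 15-fold lower number from compound 2 to compound 3 (1.18 log units; beyond the scatter). Compound 3 is therefore estimated at 1500 nM, within 300 nM to 8000 nM.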

Compound 3, half-maximal inhibitory concentration: 640 nM
The estimate for compound 3 lay 2.3-fold (0.37 log units) above the measured number; low and high end bracket the measured number.
By their numbers in this assay, from the lowest: compound 3; then compound 1; then compound 2.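

On this amine nitrogen, the step of a 35-fold lower number from compound 2 to compound 3 (1.55 log units; beyond the scatter) shows that a carbonyl is not needed in this assay: a group of one five-membered and one six-membered aromatic ring can stand in place of (3-oxocyclobutyl)carbonyl. Nothing available explains why this swap lowers the number so strongly.

The compounds shown do not reveal which of the ring nitrogens matter. They also leave open whether a single ring, such as pyrimidine or pyrazole, on the same nitrogen would serve as well as both rings together.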